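The source may hold more compounds than are shown below. What is called first, only, known or untested is meant among the compounds shown, and "the series" means these compounds.

Measured compounds:
Compound 1 `Cc1c(O)ccc2c1[C@H](Cn1cc(-c3ccc(Cl)cc3)nn1)[C@@]13CC(=O)[C@@](C)(CC[C@@H]21)C3` gives > 20000 nM in a functional assay on SMMC-7721 cells (Homo sapiens) for cytotoxicity, read by MTT assay, with a stated time of 4 days (a higher number here means a weaker inhibitor, a lower number a stronger inhibitor), a limit of the assay.
Compound 2 `Cc1ccc(S(=O)(=O)Oc2ccc3c(c2C)[C@H](Cn2cc(-c4ccc(Cl)cc4)nn2)[C@@]24CC(=O)[C@@](C)(CC[C@@H]32)C4)cc1` gives > 20000 nM in this assay, likewise a limit.
Compound 3 `C=C1C(=O)[C@]23C[C@@]1(O)CC[C@H]2c1ccc(O)c(C)c1[C@@H]3Cn1cc(-c2ccc(F)cc2)nn1` gives 850 nM in this assay.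

Compound 2 stands at the limit of this assay, a boundary of the measurement rather than a number, and it shares that boundary with compound 1 (the limit of > 20000 nM in this assay, at which 2 of the 3 values shown sit). The step that the two limits leave unreadable from compound 1 to compound 2 is therefore unreadable, both of its ends being limits. Within the data shown here, compound 3 returns a number, but it differs from compound 2 in more than one place, so the two values show only that the fluorophenyl compound with a free phenol and an altered core reaches a measurable value where compound 2 does not.

Compound 4 `COc1ccc(-c2cn(C[C@H]3c4c(ccc(OS(=O)(=O)c5ccc(C)cc5)c4C)[C@@H]4CC[C@@]5(C)C[C@]43CC5=O)nn2)cc1` differs from compound 2 by methoxy in place of chloro on an aromatic carbon. Among the measured compounds shown here, no measured step touches this position; the single measured step, from compound 1 to compound 2, concerns the oxygen on the aromatic ring and gives no readable size. The expectation rests on where compound 2 stands. Compound 4 is expected to remain near the limit, with a step that the limit leaves unreadable from compound 2 to compound 4 as the expected step, none beyond the scatter. Compound 4 is accordingly estimated at 25000 nM, within 6000 nM to 60000 nM.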

Compound 4, half-maximal inhibitory concentration: > 20000 nM
Compound 4: a limit, no number; the forecaster's own chance of this, stated with the estimate: 65%; the middle value lies beyond the limit too.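

Compound 4 gives > 20000 nM in this assay, which is a limit and not a number. The step from compound 2 to compound 4 therefore cannot be read, both ends being limits: the limit of > 20000 nM in this assay, at which 3 of the 4 values shown sit. The compounds shown leave open how large the change from 4-chlorophenyl to 4-methoxyphenyl really is, and which of the several differences between compound 2 and compound 3 goes with the measurable value of compound 3.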